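Three Measured Compounds and a Fourth to Predict

The source may hold more compounds than are shown below. What is called first, only, known or untested is meant among the compounds shown, and "the series" means these compounds.

Three compounds were measured in a functional assay on CHO cells with adenosine receptor A1 (Homo sapiens) as the target, read by cAMP accumulation and immunoassay, with a stated time of 6 min, tested at 1 uM; a higher number here means a weaker effect of the compound at the concentration tested, a lower number a stronger effect:

Compound 1 `CC(C)N1CCN(Cc2csc(N)c2C(=O)c2ccc(Cl)cc2)CC1` gives 7.3%.
Compound 2 `Nc1scc(CN2CCN(c3ccc(F)cc3Cl)CC2)c1C(=O)c1ccc(Cl)cc1` gives -39%.
Compound 3 `Nc1scc(CN2CCN(c3ccc(OC(F)(F)F)cc3)CC2)c1C(=O)c1ccc(Cl)cc1` gives -51%.

Compound 3 holds the lowest number of the three in this assay; compound 2 stands nearest, a number 12 percentage points lower from compound 2 to compound 3 (beyond the scatter), and compound 1 stands furthest, a number 58.3 percentage points lower from compound 1 to compound 3 (beyond the scatter). Compound 4 `Nc1scc(CN2CCN(c3ccccc3F)CC2)c1C(=O)c1ccc(Cl)cc1` has not been measured. It differs from compound 3 in one place: 2-fluorophenyl in place of 4-(trifluoromethoxy)phenyl on an amine nitrogen in a ring.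

Within the data shown here, the steps that bear on this change are those in which an aryl group sits on the amine nitrogen in the ring. From compound 1 to compound 2 the number fell, a number 46.3 percentage points lower from compound 1 to compound 2 (beyond the scatter), and from compound 1 to compound 3 it fell further, a number 58.3 percentage points lower from compound 1 to compound 3 (beyond the scatter). Between the two aryl compounds the gap was smaller, a number 12 percentage points lower from compound 2 to compound 3 (beyond the scatter). Compound 4 keeps an aryl group in that position, so a number in the region of compounds 2 and 3 is expected, with a modest step in this assay upward from compound 3, estimated as a number 11 percentage points higher from compound 3 to compound 4 (beyond the scatter). For compound 4 the expected value in this assay is -40%, with a range from -62% to -18%.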

Compound 4, a percentage reported as activity, at one concentration (the size of the read-out at that concentration, not a potency): -9.2%
Compound 4: the middle estimate sits 30.8 percentage points below what was measured, outside the stated range (above it).
By their numbers in this assay, from the lowest: compound 3; then compound 2; then compound 4; then compound 1.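

The aryl group on the amine nitrogen in the ring does not by itself set the read-out in this assay: 2-fluorophenyl in place of 4-(trifluoromethoxy)phenyl gives a number 41.8 percentage points higher from compound 3 to compound 4 (beyond the scatter) and in place of 2-chloro-4-fluorophenyl gives a number 29.8 percentage points higher from compound 2 to compound 4 (beyond the scatter). Replacing isopropyl with 2-fluorophenyl still gives a number 16.5 percentage points lower from compound 1 to compound 4 (beyond the scatter), yet the three aryl compounds clearly do not share one level, so the choice of aryl group matters at this position far more than the earlier gap between compound 2 and compound 3 showed. Nothing available here explains this spread.

Open, going by these compounds, is how a plain phenyl, a pyridyl or a benzyl group on that nitrogen would read. The aryl groups shown also differ from one another in more than one substituent, so the contribution of each substituent cannot be separated.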